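This account rests on a few compounds, and the source may have more. Where it says the series, first, only, none or still open, it means among the compounds named here.

Measured in a functional assay on GBM3 cells (Homo sapiens) for antiproliferative activity, read by WST assay, with a stated time of 72 h; on this read-out lower numbers stand for stronger inhibition and higher numbers for weaker inhibition:
- compound 1 `O=C(Nc1ccc(C(F)(F)F)cc1)Nc1cc2ncncc2cc1OCc1cccc(F)c1`: 6300 nM
- compound 2 `O=C(Nc1ccccc1F)Nc1cc2ncncc2cc1OCc1ccccc1`: 5900 nM
- compound 3 `O=C(Nc1cc2ncncc2cc1OCc1cccc(F)c1)Nc1cccc2ccccc12`: 1200 nM

Compound 3 has the lowest number of the three, and its gaps to compound 1 and compound 2 both lie beyond the scatter. The next compound is compound 4 `O=C(Nc1ccccc1F)Nc1cc2ncncc2cc1OCc1cccc(F)c1`, with 2-fluorophenyl in place of naphthalen-1-yl on an amide-type nitrogen.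

Going by the values given here, only one measured step touches this place: a 5.3-fold lower number from compound 1 to compound 3 (0.72 log units; beyond the scatter), which brought in the naphthalen-1-yl group. Removing that group from compound 3 is therefore expected to give a modest rise of similar size in this assay, beyond the scatter. Among the compounds with values here, compound 2 carries the same 2-fluorophenyl group and gives 5900 nM, which points the same way, although it differs from compound 4 elsewhere on the core and no measured step isolates that difference.

The expected change is a 4.2-fold higher number from compound 3 to compound 4 (0.62 log units; beyond the scatter). For compound 4 the estimated value is 5000 nM, with an expected range of 2200 nM to 10000 nM.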

Compound 4, half-maximal inhibitory concentration: 8100 nM
For compound 4 the middle estimate is 1.6-fold (0.21 log units) below the measured one; measured number inside the range.
By their numbers in this assay, from the lowest: compound 3; then compounds 2, 1 and 4 (each within the scatter of the next).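

On the amide-type nitrogen, naphthalen-1-yl now stands apart from a second phenyl group in this assay (2-fluorophenyl: a 6.8-fold higher number from compound 3 to compound 4 (0.83 log units; beyond the scatter)), which adds to the earlier step from 4-(trifluoromethyl)phenyl. The two phenyl groups themselves are not separated (a reading within the scatter: a 1.3-fold higher number from compound 1 to compound 4 (0.11 log units; within the scatter)), and fluoro in place of hydrogen on an aromatic carbon also stays within the scatter (a 1.4-fold higher number from compound 2 to compound 4 (0.14 log units; within the scatter)), so among these compounds only naphthalen-1-yl sets this position apart. No measurement at hand offers an explanation for the difference.

From the compounds shown here alone, whether naphthalen-1-yl holds its advantage on the core of compound 2 remains open. Also open, going by these compounds, is how this nitrogen would respond to a saturated cyclohexyl group, or to a phenyl group carrying an amine or a carboxylic acid.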